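The source may report more compounds than this note shows. Statements on the series, on what has been measured and on what is new or still open speak of the compounds shown alone.

Measured so far in a functional assay on NCI-H226 cells (Homo sapiens) for cytotoxicity, read by sulforhodamine B assay, with a stated time of 48 h; on this read-out higher numbers stand for weaker inhibition of growth and lower numbers for stronger inhibition of growth:

compound 1 `ClCc1ccccc1Cn1cnc2c(Cl)nc(Cl)nc21` gives 3380 nM
compound 2 `Nc1nc(Cl)c2ncn(Cc3ccc(CCl)cc3)c2n1` gives 37200 nM
compound 3 `ClCc1cccc(Cn2cnc3c(Cl)nc(Cl)nc32)c1` gives 10000 nM

Compound 1 shows the lowest number of the three, and its gaps to compound 3 and to compound 2 both lie beyond the usual scatter, so it inhibits growth most strongly. Compound 4 `Nc1nc(Cl)c2ncn(Cc3ccccc3CCl)c2n1` has not yet been measured in this assay . It differs from compound 1 in one place: amino in place of chloro on an aromatic carbon. Going by the values given here, no pair of measured compounds shows that single change on its own. Compound 2, which carries the amino group but also differs elsewhere, gives the weakest inhibition seen, so the step from compound 1 to compound 4 is expected to be a loss of growth inhibition beyond the scatter, a 4.4-fold higher number from compound 1 to compound 4 (0.65 log units; beyond the scatter). Compound 4 is therefore expected to give 15000 nM, between 5000 nM and 50000 nM.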

Compound 4, concentration for total growth inhibition: 10000 nM
Compound 4: the middle estimate sits 1.5-fold (0.18 log units) above what was measured, and the stated range covers the measured number.
By their numbers in this assay, from the lowest: compound 1; then compounds 3 and 4 (each within the scatter of the next); then compound 2.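

Going by these compounds alone, putting amino in place of chloro on the aromatic carbon between two ring nitrogen atoms gives the first direct reading of this change (a 3.0-fold higher number from compound 1 to compound 4 (0.47 log units; beyond the scatter)), a modest loss of growth inhibition. The chloro group at this position is therefore favoured over amino, yet compound 4 shows that growth inhibition survives without it. No measurement here gives a reason for the loss.

As far as these compounds go, whether a methoxy or methylamino group would fare better at this position stays open. So does whether the same change costs as much in compound 3.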